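Naphthol amides: swapping the aryl group on the carbonyl

The source may report more compounds than this note shows. Statements on the series, on what has been measured and on what is new or still open speak of the compounds shown alone.

Measured so far in a functional assay on PC-3 cells (Homo sapiens) for antiproliferative activity, read by MTT assay, with a stated time of 48 h; on this read-out lower numbers stand for stronger inhibition and higher numbers for weaker inhibition:
Compound 1 `Cc1nnc(Sc2cc(NC(=O)c3ccc(Cl)cc3)c3ccccc3c2O)s1` gives 49500 nM.
Compound 2 `O=C(Nc1cc(Sc2ncn[nH]2)c(O)c2ccccc12)c1ccc2ccccc2c1` reaches only a limit of the assay, > 100000 nM.
Compound 3 `O=C(Nc1cc(Sc2nncs2)c(O)c2ccccc12)c1ccc(Cl)cc1` also reaches only a limit of the assay, > 100000 nM.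

Compound 2 therefore stands at the edge of what this assay can report; its value is a limit and not a number, and it shares that position with compound 3, as the limit of > 100000 nM in this assay, at which 2 of the 3 values shown sit, records. Compound 1, which does give a number, is itself a weak inhibitor.

Compound 4 `O=C(/C=C/c1ccc(Cl)cc1)Nc1cc(Sc2ncn[nH]2)c(O)c2ccccc12` differs from compound 2 at a single place: 2-(4-chlorophenyl)ethenyl in place of naphthalen-2-yl on a carbonyl carbon. Going by the values given here, no measured pair differs only at that place, so none of the measured steps speaks directly to this change. Among the compounds with values here, the one measured step, an at least 2.0-fold higher number from compound 1 to compound 3 (0.30 log units; that floor lies within the scatter), concerns a different part of the molecule and lies within the scatter. What the values do show is that two compounds carrying the 4-chlorophenyl group on the carbonyl, compound 1 and compound 3, are weak or beyond the limit, just as compound 2 is.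

Compound 4 is therefore expected to remain weak, with an estimate of 80000 nM (range 20000 nM to 300000 nM), which would mean an expected step of an at least 1.2-fold lower number from compound 2 to compound 4 (0.09 log units; that floor lies within the scatter).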

Compound 4, half-maximal inhibitory concentration: > 100000 nM
Compound 4 ended at the assay's limit; the forecaster's own chance of this, stated with the estimate: 55%; at least 1.2-fold (0.09 log units) between middle value and limit.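

In this assay compound 4 gives only a limit of the assay, > 100000 nM. Going by these compounds alone, compound 2 also gives only a limit, so no step between compound 2 and compound 4 can be read. The same position is shared widely: the limit of > 100000 nM in this assay, at which 3 of the 4 values shown sit. The compounds shown leave open whether swapping naphthalen-2-yl for 2-(4-chlorophenyl)ethenyl on the carbonyl carbon changes activity at all.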